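The compounds below may be only part of what the source reports. "The series", "measured", "known", "first", "only" and "open" are said of these compounds alone.

Three compounds have been measured in an assay on isolated protein for inhibition of thiosulfate sulfurtransferase (Homo sapiens); on this read-out higher numbers stand for weaker inhibition and lower numbers for stronger inhibition:

Compound 1 `O=S(=O)(Nc1ccc(-c2nc3cc(NS(=O)(=O)c4ccccc4Cl)ccc3o2)cc1)c1ccccc1Cl` gives > 100000 nM, which is a limit of the assay.
Compound 2 `COc1ccc(S(=O)(=O)Nc2ccc3oc(-c4ccc(NC(=O)c5cccc(C)c5[N+](=O)[O-])cc4)nc3c2)cc1` gives > 100000 nM, which is a limit of the assay.
Compound 3 `O=S(=O)(Nc1ccc(-c2nc3cc(NS(=O)(=O)c4ccc(Br)cc4)ccc3o2)cc1)c1ccc(Br)cc1` gives > 100000 nM, which is a limit of the assay.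

Compound 2 therefore stands where every measured compound stands, at the limit of > 100000 nM in this assay, at which 3 of the 3 values shown sit. Going by the values given here, no number sits between two measured compounds, so no step has been measured.

Compound 4 `COc1ccc(S(=O)(=O)Nc2ccc3oc(-c4ccc(NS(=O)(=O)c5cc(F)ccc5OC)cc4)nc3c2)cc1` keeps the shared core of compound 2 and changes one group: a group of 12 heavy atoms (7 carbon, 3 oxygen, 1 fluorine, 1 sulfur; one six-membered aromatic ring of carbon only) in place of a group of 12 heavy atoms (8 carbon, 1 nitrogen, 3 oxygen; one six-membered aromatic ring of carbon only), on a nitrogen on an aromatic ring. In words, a group of 12 heavy atoms (7 carbon, 3 oxygen, 1 fluorine, 1 sulfur; one six-membered aromatic ring of carbon only) takes the place of the (3-methyl-2-nitrophenyl)carbonyl group, on a nitrogen on an aromatic ring.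

With all three measured values at the limit, the expectation for compound 4 is a step that the limit leaves unreadable from compound 2 to compound 4, which is no change beyond the scatter. In this assay compound 4 is estimated at 150000 nM, within a range from 50000 nM to 500000 nM.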

Compound 4, half-maximal inhibitory concentration: > 100000 nM
Compound 4 ended at the assay's limit (the forecaster's own chance of this, stated with the estimate: 85%); the middle value is on the limit's open side.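

In this assay compound 4 gives > 100000 nM, which is a limit of the assay. Compound 2 also sits at a limit, so the step from compound 2 to compound 4 cannot be read. The compounds shown leave open which change to the shared core, if any, would give a value readable as a number, since all of them sit together: the limit of > 100000 nM in this assay, at which 4 of the 4 values shown sit.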